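This account rests on a few compounds, and the source may have more. Where it says the series, first, only, none or still open, it means among the compounds named here.

Series in a functional assay on CCRF-CEM cells (Homo sapiens); on this read-out higher numbers stand for lower toxicity in this test and lower numbers for higher toxicity in this test:
compound 1 `Cc1cn([C@@H]2O[C@H](CO[Si](C)(C)C(C)(C)C)[C@@]3(OS(=O)(=O)C=C3NC(=O)c3ccccc3)[C@H]2O[Si](C)(C)C(C)(C)C)c(=O)n(C)c1=O` gives 4910 nM
compound 2 `Cc1cn([C@@H]2O[C@H](CO[Si](C)(C)C(C)(C)C)[C@@]3(OS(=O)(=O)C=C3NCCC(=O)O)[C@H]2O[Si](C)(C)C(C)(C)C)c(=O)n(C)c1=O` gives 19400 nM
compound 3 `Cc1cn([C@@H]2O[C@@H]3COC(=O)[C@]3(OS(C)(=O)=O)[C@H]2O)c(=O)[nH]c1=O` gives 160000 nM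

Compound 2 holds the second highest number of the three in this assay; compound 1 sits closest, compound 3 furthest, both beyond the scatter.

Compound 4 `Cc1cn([C@@H]2O[C@H](CO[Si](C)(C)C(C)(C)C)[C@@]3(OS(=O)(=O)C=C3NCC(N)=O)[C@H]2O[Si](C)(C)C(C)(C)C)c(=O)n(C)c1=O` differs from compound 2 as follows: carbamoyl in place of carboxymethyl on a saturated chain carbon bound to an amine nitrogen

Within the data shown here, the only measured step that touches this part of the molecule is a 4.0-fold higher number from compound 1 to compound 2 (0.60 log units; beyond the scatter), where a 2-carboxyethyl group replaced a benzoyl group on the amine nitrogen. Among the measured compounds shown here, no measured pair shows the carboxymethyl to carbamoyl swap itself, so the direction is uncertain; a modest step back toward compound 1 is expected, with a 1.6-fold lower number from compound 2 to compound 4 (0.21 log units; within the scatter) carrying it. Compound 4 is therefore estimated at 12000 nM in this assay, within 4000 nM to 40000 nM.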

Compound 4, half-maximal cytotoxic concentration: 14600 nM
Compound 4: middle estimate off by 1.2-fold (0.09 log units), on the low side; measured number inside the range.
By their numbers in this assay, from the lowest: compound 1; then compounds 4 and 2 (each within the scatter of the next); then compound 3.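

In this assay the step of a 1.3-fold lower number from compound 2 to compound 4 (0.12 log units; within the scatter) stays within the scatter, so carbamoyl and carboxymethyl on a saturated chain carbon bound to an amine nitrogen cannot be told apart here. The step of a 3.0-fold higher number from compound 1 to compound 4 (0.47 log units; beyond the scatter) shows a second group, carbamoylmethyl, that like 2-carboxyethyl gives a higher number than benzoyl on the amine nitrogen. No measurement at hand accounts for either step. Still open, as far as these compounds go, is whether a simple amine or a longer chain ending in carbamoyl on that nitrogen would sit with compound 4 or with compound 1.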